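Methyl for chloro on the benzyl ring, now at the meta position

The source may report more compounds than this note shows. Statements on the series, on what has been measured and on what is new or still open speak of the compounds shown alone.

Of the compounds shown here, three have been tested in a functional assay on L6 cells (Rattus norvegicus) for inhibition; a higher number here means a weaker inhibitor, a lower number a stronger inhibitor. Compound 1 `Cc1ccccc1CNC(=O)c1nn(-c2ccc(F)cc2)c(OC[C@@H](O)C[C@@H](O)CC(=O)O)c1C(C)C` gives 2850 nM. Compound 2 `CC(C)c1c(C(=O)NCc2ccccc2Cl)nn(-c2ccc(F)cc2)c1OC[C@@H](O)C[C@@H](O)CC(=O)O` gives 8450 nM. Compound 3 `CC(C)c1c(C(=O)N(C)Cc2cccc(Cl)c2)nn(-c2ccc(F)cc2)c1OC[C@@H](O)C[C@@H](O)CC(=O)O` gives 2120 nM.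

Compounds 2 and 1 differ only by methyl in place of chloro on an aromatic carbon, which brought a 3.0-fold lower number from compound 2 to compound 1 (0.47 log units; beyond the scatter). Compound 3 differs from compound 2 by (3-chlorobenzyl)(methyl)amino in place of (2-chlorobenzyl)amino on a carbonyl carbon, giving a 4.0-fold lower number from compound 2 to compound 3 (0.60 log units; beyond the scatter); from compound 1 to compound 3 the gap is a 1.3-fold lower number from compound 1 to compound 3 (0.13 log units; within the scatter).

As far as these compounds go, compound 4 `Cc1cccc(CN(C)C(=O)c2nn(-c3ccc(F)cc3)c(OC[C@@H](O)C[C@@H](O)CC(=O)O)c2C(C)C)c1` is untested. It differs from compound 3 by methyl in place of chloro on an aromatic carbon. This is the same kind of change as that from compound 2 to compound 1, but not the same: there the methyl sat ortho to a large group, here it sits meta to a large group, on a core that also carries the methyl on the amide nitrogen.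

Because the earlier change gave a 3.0-fold lower number from compound 2 to compound 1 (0.47 log units; beyond the scatter), a lower number is expected for compound 4 as well, though the shifted position leaves the size uncertain; the expected step is a 1.9-fold lower number from compound 3 to compound 4 (0.28 log units; within the scatter). Compound 4 is therefore estimated at 1100 nM, with a likely range from 450 nM to 3000 nM.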

Compound 4, half-maximal inhibitory concentration: 18500 nM
The estimate for compound 4 lay 17-fold (1.23 log units) below the measured number; the measured number lies above the stated range.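

In this assay, methyl in place of chloro gives an 8.7-fold higher number from compound 3 to compound 4 (0.94 log units; beyond the scatter). This change does not carry over from one core to the other, and the direction of the step reverses: the same change on two cores in this assay, a 3.0-fold lower number (0.47 log units; beyond the scatter) from compound 2 to compound 1 and an 8.7-fold higher number (0.94 log units; beyond the scatter) from compound 3 to compound 4, 26-fold (1.41 log units) apart, beyond the scatter of two such steps

Compound 4 also has the highest number of the four, with a 2.2-fold higher number from compound 2 to compound 4 (0.34 log units; beyond the scatter) and a 6.5-fold higher number from compound 1 to compound 4 (0.81 log units; beyond the scatter), so it is the weakest inhibitor shown. What this does not show is the source of the reversal: the two pairs differ both in where the swapped group sits on the benzyl ring and in the methyl on the amide nitrogen, and these two differences cannot be separated here.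

The compounds shown leave open how the 3-chlorobenzyl and 3-methylbenzyl groups behave with the amide hydrogen in place of that methyl, and how the 2-chlorobenzyl and 2-methylbenzyl groups behave with the methyl on the amide nitrogen. They also leave open whether another group in the same place, such as fluoro or methoxy, would follow chloro or methyl.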